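The source may report more compounds than this note shows. Statements on the series, on what has been measured and on what is new or still open speak of the compounds shown alone.

Compound 1 `CCc1ccc2nc(C(=O)Nc3c(F)cc(-c4cccc(F)c4)cc3F)c(C)c(O)c2c1`: 31.2%
Compound 2 `CCc1ccc2nc(C(=O)Nc3c(F)cc(-c4cccc(F)c4)cc3F)c(C)c(C(=O)O)c2c1`: 15.2%

Among the compounds with values here, in a functional assay on Hep 3B2 cells (Homo sapiens) for antiproliferative activity, read by MTT assay, with a stated time of 24 h, tested at 3.7 ug/mL (a higher number here means a stronger effect of the compound at the concentration tested, a lower number a weaker effect), compound 2 stands lowest of the two numbers, separated from its only neighbour by a number 16 percentage points lower from compound 1 to compound 2 (beyond the scatter). Compound 3 `CCOc1ccc2nc(C(=O)Nc3c(F)cc(-c4cccc(F)c4)cc3F)c(C)c(C(=O)O)c2c1` differs from compound 2 in one place: ethoxy in place of ethyl on an aromatic carbon. Within the data shown here, the single measured step concerns carboxy in place of hydroxy, a different position, so no measured step bears on this change and no direction can be read from the data. Compound 3 is therefore estimated near compound 2, with an expected step of a number 0.2 percentage points lower from compound 2 to compound 3 (within the scatter) in this assay. The estimate for compound 3 is 15%, within 3% to 32%.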

Compound 3, a percentage reported as inhibition, at one concentration (the size of the read-out at that concentration, not a potency): 26.5%
For compound 3 the middle estimate is 11.5 percentage points below the measured one; the range from low to high includes it.
By their numbers in this assay, from the lowest: compound 2; then compounds 3 and 1 (each within the scatter of the next).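

In this assay the aromatic carbon carrying the ethyl group proves sensitive to substitution, with the carboxy group held constant: ethoxy in place of ethyl gives a number 11.3 percentage points higher from compound 2 to compound 3 (beyond the scatter). Within the data shown here, this is the only measured change at this position, and unlike the earlier step, which concerned carboxy in place of hydroxy elsewhere, it shows a direction here. Nothing measured here explains this step. Open, on these data alone, is whether a longer chain such as propoxy or an amine at this carbon would give a similar number, and whether ethoxy has the same effect with hydroxy in place of carboxy.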